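The source may report more compounds than this note shows. Statements on the series, on what has been measured and on what is new or still open speak of the compounds shown alone.

Measured compounds in a functional assay on MOLT-4 cells (Homo sapiens) for antiproliferative activity; a higher number here means a weaker inhibitor, a lower number a stronger inhibitor:
compound 1, `COc1cc(C(=O)c2sc(-c3ccc(Cl)cc3)cc2N)cc(OC)c1OC`, 77 nM
compound 2, `COc1cc(C(=O)c2sc(-c3ccncc3)cc2N)cc(OC)c1OC`, 88 nM

Compound 2 sits alongside compound 1 on the numbers shown: the step of a 1.1-fold higher number from compound 1 to compound 2 (0.06 log units; within the scatter) is within the scatter, so the two values cannot be told apart, and compound 2 is simply the second of two closely placed points.

Compound 3, `COc1cc(C(=O)c2sc(-c3ccc(C)cc3)cc2N)cc(OC)c1OC`, is not yet measured. It differs from compound 2 as follows: 4-methylphenyl in place of pyridin-4-yl on an aromatic carbon.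

Among the measured compounds shown here, the only measured step that bears on this is the exchange at the same aromatic carbon, a 1.1-fold higher number from compound 1 to compound 2 (0.06 log units; within the scatter), where one six-membered ring replaced another and the number barely moved. On that basis the exchange to 4-methylphenyl is expected to give no step beyond the scatter, so a 1.1-fold lower number from compound 2 to compound 3 (0.04 log units; within the scatter) is the estimated change.

Compound 3 is therefore expected to give 80 nM in this assay, with a likely range from 40 nM to 160 nM.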

Compound 3, half-maximal inhibitory concentration: 16 nM
Compound 3: middle estimate off by 5.0-fold (0.70 log units), on the high side; the whole stated range lies above it.
By their numbers in this assay, from the lowest: compound 3; then compounds 1 and 2 (each within the scatter of the next).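

Notes on the series: in this assay the group on the aromatic carbon next to the ring sulfur is not interchangeable, as shown by a 5.5-fold lower number from compound 2 to compound 3 (0.74 log units; beyond the scatter) and by a 4.8-fold lower number from compound 1 to compound 3 (0.68 log units; beyond the scatter) with both steps beyond the scatter, whereas compound 1 and compound 2 could not be told apart. Methyl in place of chloro, with the rest of compound 1 unchanged, is enough to move the number, so the group carried on this ring matters as well as the ring itself. No measurement at hand accounts for this difference.

Going by these compounds, whether the gain is particular to methyl or extends to ethyl, methoxy or an amine at that place on the ring remains open. Also open, on these data alone, is whether the same order holds for these compounds in other cell lines.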